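Swapping the Aryl Group on a Carbonyl Carbon

The compounds below may be only part of what the source reports. "The series", "measured", "known", "first", "only" and "open" are said of these compounds alone.

Of the compounds shown here, three sharing one core have been tested in a functional assay on MDA-MB-231 cells (Homo sapiens) for antiproliferative activity, read by MTT assay, with a stated time of 72 h; a higher number here means a weaker inhibitor, a lower number a stronger inhibitor. Compound 1 `CC(=O)O[C@H]1CC[C@]2(C)[C@H](CC[C@@](C)(O)[C@H]2CC[C@@H]2C(C)=CC[C@H]3[C@H](CC[C@]3(C)O)C2(C)C)OC1(C)C` gives 38000 nM, compound 2 `CC1=CC[C@H]2[C@H](CC[C@]2(C)O)C(C)(C)[C@@H]1CC[C@H]1[C@]2(C)CC[C@H](OC(=O)CCC(=O)O)C(C)(C)O[C@H]2CC[C@@]1(C)O` gives 27900 nM, and compound 3 `COc1ccc(C(=O)O[C@H]2CC[C@]3(C)[C@H](CC[C@@](C)(O)[C@H]3CC[C@@H]3C(C)=CC[C@H]4[C@H](CC[C@]4(C)O)C3(C)C)OC2(C)C)cc1` gives 30600 nM. Compound 3 therefore cannot be separated from either of the other two on these numbers. Compound 4 `CC1=CC[C@H]2[C@H](CC[C@]2(C)O)C(C)(C)[C@@H]1CC[C@H]1[C@]2(C)CC[C@H](OC(=O)c3ccccc3Cl)C(C)(C)O[C@H]2CC[C@@]1(C)O` differs from compound 3 in one place: 2-chlorophenyl in place of 4-methoxyphenyl on a carbonyl carbon. In words, it has 2-chlorophenyl in place of 4-methoxyphenyl on a carbonyl carbon.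

Two measured steps changed the group at this same place: a 1.2-fold lower number from compound 1 to compound 3 (0.09 log units; within the scatter) and a 1.1-fold higher number from compound 2 to compound 3 (0.04 log units; within the scatter). A third, a 1.4-fold lower number from compound 1 to compound 2 (0.13 log units; within the scatter), completes the set, and none of the three exceeds the scatter. For the measured compounds named here, none of the measured compounds carries 2-chlorophenyl, so that group itself remains untested. Even so, no step beyond the scatter is expected in this assay. The expected change is a 1.0-fold lower number from compound 3 to compound 4 (0.01 log units; within the scatter). For compound 4 the estimated value is 30000 nM, with an expected range from 16000 nM to 55000 nM.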

Compound 4, half-maximal inhibitory concentration: 24300 nM
For compound 4 the middle estimate is 1.2-fold (0.09 log units) above the measured one; the measured number falls inside the stated range.
By their numbers in this assay, from the lowest: compounds 4, 2, 3 and 1 (each within the scatter of the next).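

In this assay, 2-chlorophenyl on this carbonyl carbon is not separated from any of the three groups measured earlier, as the steps show (a 1.3-fold lower number from compound 3 to compound 4 (0.10 log units; within the scatter)) and (a 1.1-fold lower number from compound 2 to compound 4 (0.06 log units; within the scatter)) and (a 1.6-fold lower number from compound 1 to compound 4 (0.19 log units; within the scatter)). Chlorine on the aromatic ring, which none of the earlier compounds carried, thus adds a fourth group at this place, and all the steps among compounds 1, 2, 3 and 4 stay within the scatter. No measurement bearing on this result is available to explain it.

From the compounds shown here alone, what remains open is whether a group such as an amine, a nitrile or a longer chain on this carbonyl carbon would give a step beyond the scatter. The compounds shown also leave open whether replacing the ester oxygen with an amide nitrogen would change the number.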